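Trimethylphenyl in Place of Trifluorophenyl on the Urea Nitrogen

The source may hold more compounds than are shown below. What is called first, only, known or untested is meant among the compounds shown, and "the series" means these compounds.

compound 1 `Cc1cc(C)c(NC(=O)N(Cc2ccc(-c3cccs3)cc2)C2CCCCCC2)c(C)c1`: 0.28 mg/kg
compound 2 `O=C(Nc1c(F)cc(F)cc1F)N(Cc1ccc(-c2ccsc2)cc1)C1CCCCCC1`: > 1 mg/kg

In a functional assay on a cell-free system (plasma) with sterol O-acyltransferase, Soat (Rattus norvegicus) as the target (on this read-out lower numbers stand for an effect already at smaller amounts and higher numbers for an effect only at larger amounts of compound), compound 1 gives 0.28 mg/kg. For compound 2 only a limit of the assay is known, > 1 mg/kg, which is the limit of > 1 mg/kg in this assay, at which 1 of the 2 values shown sits. Compound 3 `Cc1cc(C)c(NC(=O)N(Cc2ccc(-c3ccsc3)cc2)C2CCCCCC2)c(C)c1` differs from compound 2 by 2,4,6-trimethylphenyl in place of 2,4,6-trifluorophenyl on an amide-type nitrogen. Compound 1 carries the same 2,4,6-trimethylphenyl group and reaches a measured number, so a step from compound 2 toward smaller doses is expected, estimated as an at least 2.5-fold lower number from compound 2 to compound 3 (0.39 log units; beyond the scatter), well beyond the usual scatter. Compound 3 is therefore estimated at 0.4 mg/kg in this assay, with a likely range from 0.15 mg/kg to 1.2 mg/kg.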

Compound 3, dose for half-maximal effect: 0.51 mg/kg
Beside the measured number, compound 3's estimate is 1.3-fold (0.11 log units) below it; the measured number falls inside the stated range.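

On the amide-type nitrogen, 2,4,6-trimethylphenyl in place of 2,4,6-trifluorophenyl gives an at least 1.9-fold lower number from compound 2 to compound 3 (0.29 log units; that floor lies within the scatter) and so does not yet establish a real gain. As far as these compounds go, the size of this step stays open, and it can only be read as a floor: the limit of > 1 mg/kg in this assay, at which 1 of the 3 values shown sits. Thiophen-3-yl in place of thiophen-2-yl gives a 1.8-fold higher number from compound 1 to compound 3 (0.26 log units; within the scatter) and so shows no real separation between these two attachments.

Still open, from the compounds shown here alone, is how a phenyl ring carrying an amine or a carboxylic acid would behave on this nitrogen.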